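Sulfur to Tellurium at the Chain End

The source may hold more compounds than are shown below. What is called first, only, known or untested is meant among the compounds shown, and "the series" means these compounds.

Of the compounds shown here, three have been measured in an ADME assay on cells (Fibroblast, Homo sapiens) for cytotoxicity, read by MTT assay, with a stated time of 24 h; on this read-out lower numbers stand for stronger inhibition and higher numbers for weaker inhibition. Compound 1 `COc1ccc(N(CC(=O)NCCCSc2ccccc2)C(=O)CCSC2=C(C)C(=O)c3ccccc3C2=O)cc1` gives 26000 nM there. Compound 2 `COc1ccc(N(CC(=O)NCCC[Te]c2ccccc2)C(=O)CNC(=O)OC(C)(C)C)cc1`, which carries tellurium in its side chain and a different acyl group, gives 25000 nM in this assay, and the two numbers sit within the usual scatter of each other, so neither can be ranked against the other. Compound 3 `COc1ccc(N(CC(=O)NCCC[Se]c2ccccc2)C(=O)c2ccccc2)cc1` reaches only the limit of this assay, >= 100000 nM (the limit of >= 100000 nM in this assay, at which 1 of the 3 values shown sits). Of the two numeric values shown, compound 1 holds the higher one.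

Compound 4 `COc1ccc(N(CC(=O)NCCC[Te]c2ccccc2)C(=O)CCSC2=C(C)C(=O)c3ccccc3C2=O)cc1` has not yet been measured in this assay. It differs from compound 1 in one place: a group of 7 heavy atoms (6 carbon, 1 tellurium; one six-membered aromatic ring of carbon only) in place of a group of 7 heavy atoms (6 carbon, 1 sulfur; one six-membered aromatic ring of carbon only), on a saturated chain carbon, three bonds along the chain from an amide-type nitrogen. Going by the values given here, no pair of measured compounds differs by this exchange alone, so no measured step can be quoted for it. What the data do show is that compound 2, which also carries the tellurium-bearing chain, gives a number in the same region as compound 1, though compound 2 differs in its acyl group as well. For compound 4 the step is therefore expected to be small, a 1.3-fold lower number from compound 1 to compound 4 (0.11 log units; within the scatter), not clearly beyond the scatter. Compound 4 is expected to give 20000 nM, within a range from 8000 nM to 50000 nM.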

Compound 4, half-maximal inhibitory concentration: 4000 nM
Compound 4: the middle estimate sits 5.0-fold (0.70 log units) above what was measured, and the stated range ends above it.
By their numbers in this assay, from the lowest: compound 4; then compounds 2 and 1 (each within the scatter of the next). At a limit, above all of these: compound 3.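

In this assay, going by these compounds alone, the exchange of phenylsulfanyl for its tellurium-bearing counterpart, on a saturated chain carbon, three bonds along the chain from an amide-type nitrogen, gives a 6.5-fold lower number from compound 1 to compound 4 (0.81 log units; beyond the scatter) and is the only single-place step read so far. Within the data shown here, it shows that the chalcogen atom at this chain end can move the number beyond the scatter on its own, with the rest of compound 1 left unchanged, which the earlier compounds could not show, as each of them differed from the others in more than one place. Nothing measured here accounts for the size of this step.

The compounds shown leave open whether the same exchange gives a step of like size when the acyl group of compound 1 gives way to that of compound 2 or compound 3, and where selenium falls at this position with the acyl group of compound 1 kept. They also leave open whether the step survives when the phenyl ring on tellurium is replaced by a methyl group, or when the chain leading to it is made longer.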